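Cytotoxicity notes on the shared core series

The source may hold more compounds than are shown below. What is called first, only, known or untested is meant among the compounds shown, and "the series" means these compounds.

In an ADME assay on Vero cells (Chlorocebus sabaeus) for cytotoxicity, read by resazurin assay, with a stated time of 3 days (on this read-out higher numbers stand for weaker inhibition and lower numbers for stronger inhibition), compound 1, `CCCCNC(=O)Nc1cc2nc(C3CCCCC3)[nH]c2cc1N(CC)CC`, gives only a limit, > 100 ug/mL. Compound 2, `CCOCCOC(=O)Nc1cc2nc(C3CCCCC3)[nH]c2cc1N1CCCC1`, likewise gives only a limit in this assay, > 100 ug/mL. Compound 2 thus stands at the limit of > 100 ug/mL in this assay, at which 2 of the 2 values shown sit, with no number behind it. Compound 3, `CCOCCOC(=O)Nc1cc2nc(C3CCCCC3)[nH]c2cc1N(CC)CC`, carries diethylamino in place of pyrrolidin-1-yl on an aromatic carbon. The same group stands in compound 1, which in this assay gives only a limit, > 100 ug/mL. For the measured compounds named here, no step between measured compounds is known, and no shift beyond the scatter is expected for compound 3. The step from compound 2 to compound 3 is expected to be a step that the limit leaves unreadable from compound 2 to compound 3. Compound 3 is estimated at 150 ug/mL, between 70 ug/mL and 400 ug/mL, most likely reported again as a limit.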

Compound 3, half-maximal inhibitory concentration: > 100 ug/mL
Compound 3 gave a limit, no number; the forecaster's own chance of this, stated with the estimate: 85%; the middle value does not contradict the limit.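

No step can be read among compound 1, compound 2 and compound 3 in this assay, as each gives only a limit: the limit of > 100 ug/mL in this assay, at which 3 of the 3 values shown sit. The compounds shown leave open whether either exchange on the shared core shifts the read-out at all.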